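Adding a Third Methoxy to a Weakly Active Lactam

The source may hold more compounds than are shown below. What is called first, only, known or untested is meant among the compounds shown, and "the series" means these compounds.

Compound 1 `COc1ccc(/C=C/C2CC=CC(=O)O2)cc1` and compound 2 `COc1ccc(/C=C/C2CC=CC(=O)O2)c(OC)c1` share one core and differ in a single place: methoxy in place of hydrogen on an aromatic carbon. In a functional assay on OVCAR-3 cells (Homo sapiens) for inhibition, read by sulforhodamine B assay, with a stated time of 48 h (a higher number here means a weaker inhibitor of growth, a lower number a stronger inhibitor of growth), compound 1 gives 61.5 uM, while compound 2 gives 5.6 uM, and the step of an 11-fold lower number from compound 1 to compound 2 (1.04 log units; beyond the scatter). Compound 3 `COc1ccc(/C=C/C2CC=CC(=O)N2)cc1OC` has a different core; the difference between the core of compound 3 and the core of compound 1 is not broken down here. In this assay compound 3 reaches only a limit of the measurement, > 964 uM, which is the point noted as the limit of > 964 uM in this assay, at which 1 of the 3 values shown sits. Compound 4 `COc1cc(OC)c(OC)cc1/C=C/C1CC=CC(=O)N1` differs from compound 3 by the same kind of change, (methoxy in place of hydrogen on an aromatic carbon); around this place the ring also carries a methoxy group para to the new group, so the surroundings are not the same as in the earlier step. The expectation for compound 4 rests on the size of the step of an 11-fold lower number from compound 1 to compound 2 (1.04 log units; beyond the scatter). A step of about an at least 2.4-fold lower number from compound 3 to compound 4 (0.38 log units; beyond the scatter) is expected from compound 3 to compound 4, although the starting point is itself only a limit. Compound 4 is therefore expected to give roughly 400 uM in this assay, most likely between 60 uM and 2500 uM, with a real chance that again only a limit is reported.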

Compound 4, concentration for growth inhibition (reported as GI): > 864 uM
Compound 4: a limit, no number (the forecaster's own chance of this, stated with the estimate: 45%); middle value at least 2.1-fold (0.33 log units) away from the limit.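

Compound 3 and compound 4 both stand only as limits, not numbers, in this assay, so the step from one to the other cannot be read. The compounds shown leave open whether methoxy in place of hydrogen on an aromatic carbon changes growth inhibition on the core of compound 3 as it does on the core of compound 1.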